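Replacing 4-methoxyphenyl with isobutyl on a carbonyl carbon

The source may hold more compounds than are shown below. What is called first, only, known or untested is meant among the compounds shown, and "the series" means these compounds.

Of the compounds shown here, two have so far been measured in a functional assay on HCT-116 cells (Homo sapiens) for inhibition, read by sulforhodamine B assay, with a stated time of 3 days; on this read-out lower numbers stand for stronger inhibition and higher numbers for weaker inhibition. Compound 1 `O=C1Nc2ccccc2/C1=C\C(=O)c1c[nH]c2ccccc12` gives 860 nM as its half-maximal inhibitory concentration. Compound 2 `COc1ccc(C(=O)Nc2ccc3c(c2)/C(=C/Nc2cccc(N4CCN(C)CC4)c2)C(=O)N3)cc1` gives 2010 nM and so holds the higher of the two numbers, which means the weaker inhibition, and the gap between the pair lies beyond the usual scatter.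

Compound 3 `CC(C)CC(=O)Nc1ccc2c(c1)/C(=C/Nc1cccc(N3CCN(C)CC3)c1)C(=O)N2` departs from compound 2 in one place, and the difference is isobutyl in place of 4-methoxyphenyl on a carbonyl carbon. In plain terms, isobutyl stands in place of 4-methoxyphenyl on a carbonyl carbon, so the ring of compound 2 is lost from that position. Among the measured compounds shown here, no measured pair in this small set shows this kind of exchange, and the expectation can lean only on compound 2 at 2010 nM as its starting point. With so little evidence, no shift beyond the scatter is expected, and the estimated change is a 1.1-fold lower number from compound 2 to compound 3 (0.05 log units; within the scatter) in this assay on this basis. For compound 3 the estimate is 1800 nM with 600 nM to 5000 nM as its expected range.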

Compound 3, half-maximal inhibitory concentration: 9410 nM
Compound 3: middle estimate off by 5.2-fold (0.72 log units), on the low side; measured number above the stated range.
By their numbers in this assay, from the lowest: compound 1; then compound 2; then compound 3.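

Isobutyl in place of 4-methoxyphenyl on a carbonyl carbon whose other neighbour is an amide-type nitrogen gives a 4.7-fold higher number from compound 2 to compound 3 (0.67 log units; beyond the scatter) in this assay and so means weaker inhibition. Among the compounds shown here, the earlier compounds held no pair that changed only this group, so this is the first sign that inhibition in these cells depends on what sits on this carbonyl carbon, and here the weaker number goes with the group that has no ring, 4 heavy atoms rather than 8 and no hydrogen-bond acceptor. For the compounds shown here, nothing measured so far accounts for the size or direction of this step.

From the compounds shown here alone, a single exchange changes all of these features at once, so it remains open whether the aromatic ring, the methoxy oxygen or the plain count of heavy atoms goes with the lower number, and how a phenyl without the methoxy or a cyclohexyl would read on this carbonyl carbon. One pair also leaves open whether the same exchange would give a similar step with the rest of the shared core changed.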